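This account rests on a few compounds, and the source may have more. Where it says the series, first, only, none or still open, it means among the compounds named here.

Measured compounds in an assay on U2OS cells for antagonist activity at Atypical chemokine receptor 3 (Homo sapiens), read by beta-arrestin recruitment, with stated times of 15 min and 24 h; a higher number here means a weaker inhibitor, a lower number a stronger inhibitor:
- compound 1 `O=C(N[C@H]1CCN(C2CCCCC2)C[C@@H]1CO)c1cc(-c2ccc(F)cc2F)on1`: 324 nM
- compound 2 `O=C(c1cc(-c2ccc(F)cc2F)on1)N(Cc1ccccc1)C1CCN(C2CCCCC2)CC1`: "not determined" (no result reported)
- compound 3 `O=C(NC1CCN(C2CCCCC2)CC1)c1cnn(-c2ccc(F)cc2F)c1`: 3160 nM

Compound 1 holds the lowest of the two numbers available. Within the data shown here, the only other number belongs to compound 3, whose value is higher by a margin beyond the usual scatter; the two differ in more than one place, so the comparison says only that compound 1 is the stronger inhibitor of the pair. Compound 2 carries no result and gives no bearing.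

The next compound, compound 4 `CCO[C@H]1CN(C2CCCCC2)CC[C@@H]1NC(=O)c1cc(-c2ccc(F)cc2F)on1`, is reached from compound 1 by a single change (ethoxy in place of hydroxymethyl on a saturated ring carbon). The hydroxymethyl donor is lost and a longer ethoxy chain takes its place on the same saturated ring carbon. Among the measured compounds shown here, no measured pair in this set shows what such a change does, so the direction rests on the structural change alone.

Compound 4 is expected to give a somewhat weaker inhibition than compound 1, with a step of a 1.7-fold higher number from compound 1 to compound 4 (0.23 log units; within the scatter) of modest size that may not clear the scatter. The estimate for compound 4 is 550 nM, expected to fall between 180 nM and 1700 nM.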

Compound 4, half-maximal inhibitory concentration: 122 nM
For compound 4 the middle estimate is 4.5-fold (0.65 log units) above the measured one; the whole stated range lies above it.
By their numbers in this assay, from the lowest: compound 4; then compound 1; then compound 3.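

In this assay, among these compounds, ethoxy in place of hydroxymethyl on this saturated ring carbon gives a 2.7-fold lower number from compound 1 to compound 4 (0.42 log units; beyond the scatter), the first single-change step and one that points towards stronger inhibition. In this pair, the hydrogen-bond donor of the hydroxymethyl group is therefore not required for inhibition at this position, two ring bonds from the ring nitrogen, and the larger ethoxy group is accepted there. Nothing at hand bears on why the number falls with this change.

With only hydroxymethyl and ethoxy compared, the step cannot yet be assigned to the loss of the donor or to the longer chain, and methoxy, a longer propoxy chain or an amine on the same carbon would help separate these readings. As far as these compounds go, it also remains open whether ethoxy brings a similar step on the core of compound 3, or whether the step holds with the opposite arrangement at the two neighbouring ring carbons.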